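A few compounds are considered here, and "the series" means these few. Any claim that something is new, unique, unknown or untested is made for them only; others in the source may bear on it.

Values in an ADME assay on L929 cells (Mus musculus) for cytotoxicity, read by resazurin assay, with a stated time of 48 h; on this read-out higher numbers stand for lower toxicity in this test and lower numbers for higher toxicity in this test:
- compound 1 `O=C(O)CCCn1c2ccc([N+](=O)[O-])cc2c(=O)n1Cc1ccccc1`: > 256000 nM
- compound 2 `CCOC(=O)n1c2ccc([N+](=O)[O-])cc2c(=O)n1Cc1ccccc1`: 122000 nM

The entry for compound 1 is a limit. For the measured compounds named here, compound 2 holds the only actual number so far, 122000 nM. Compound 3 `O=C(c1ccccc1)n1c2ccc([N+](=O)[O-])cc2c(=O)n1Cc1ccccc1` has phenyl in place of ethoxy on a carbonyl carbon, ethoxycarbonyl to benzoyl: phenyl in place of ethoxy on a carbonyl carbon. Going by the values given here, the single measured step, an at least 2.0-fold lower number from compound 1 to compound 2 (0.32 log units; beyond the scatter), is at least modest and rests on a limit, so it gives only a loose guide. A step of a 1.4-fold lower number from compound 2 to compound 3 (0.13 log units; within the scatter) is expected, with none beyond the scatter. Compound 3 is estimated at 90000 nM, with an expected range of 35000 nM to 230000 nM.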

Compound 3, concentration lethal to 50% of the cells: 146000 nM
For compound 3 the middle estimate is 1.6-fold (0.21 log units) below the measured one, and the stated range covers the measured number.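

Phenyl in place of ethoxy on the carbonyl carbon leaves the values within the scatter in this assay: a 1.2-fold higher number from compound 2 to compound 3 (0.08 log units; within the scatter). On this aromatic nitrogen, benzoyl thus reads like ethoxycarbonyl, and the added aromatic ring brings no separable shift. Against 3-carboxypropyl, the reading is an at least 1.7-fold lower number from compound 1 to compound 3 (0.24 log units; that floor lies within the scatter), so this step does not on its own confirm the gap seen with ethoxycarbonyl, and the entry for compound 1 is a limit: the limit of > 256000 nM in this assay, at which 1 of the 3 values shown sits.

Open, going by these compounds, is whether an amine or a longer alkyl chain on the carbonyl carbon would move the number beyond the scatter. Also open, on these data alone, is how far compound 1 actually lies from compound 2 and compound 3.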